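Boron-bearing anilinoquinazolines: fluoro removal at the aniline

A few compounds are considered here, and "the series" means these few. Any claim that something is new, unique, unknown or untested is made for them only; others in the source may bear on it.

Of the compounds shown here, three have been measured in an assay on isolated protein for inhibition of vascular endothelial growth factor receptor 1 (Homo sapiens), read by ELISA, with a stated time of 20 min, tested at 1 uM; on this read-out higher numbers stand for more inhibition at the one concentration tested (going by the name of the read-out) and lower numbers for less inhibition. Compound 1 `COc1cc2ncnc(Nc3cccc(Cl)c3)c2cc1B1OC(C)(C)C(C)(C)O1` is recorded in this assay as "not active" (no number reported), with no number given. Compound 2 `OB(O)c1ccc2ncnc(Nc3cccc(Cl)c3)c2c1` gives 7% in this assay. Compound 3 `CC1(C)OB(c2ccc3ncnc(Nc4ccc(F)c(Cl)c4)c3c2)OC1(C)C` gives 8% in this assay; of the two numbers available it stands alongside compound 2, the two values lying within the usual scatter of each other, so no order between them can be read. Among the measured compounds shown here, all numbers in hand are small, and no pair of measured compounds differs in only one place, so no step size is established.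

Compound 4 `CC1(C)OB(c2ccc3ncnc(Nc4cccc(Cl)c4)c3c2)OC1(C)C` is not yet measured. It differs from compound 3 by hydrogen in place of fluoro on an aromatic carbon. For the measured compounds named here, no measured pair shows the effect of this change. Given that every number so far is low and close to the others, the expectation for the step from compound 3 to compound 4 is a number 1 percentage points lower from compound 3 to compound 4 (within the scatter), that is, nothing beyond the scatter in either direction. On that basis compound 4 is estimated to give 7% in this assay, with a range from 0% to 18%, and with some chance that it is reported without a number, as compound 1 was.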

Compound 4, a percentage reported as inhibition, at one concentration (the size of the read-out at that concentration, not a potency): 12%
Compound 4: the middle estimate sits 5 percentage points below what was measured; the measured number falls inside the stated range.
By their numbers in this assay, from the lowest: compounds 2, 3 and 4 (each within the scatter of the next).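

Hydrogen in place of fluoro on the aromatic carbon ortho to the chloro group and para to a large group gives, in this assay, a number 4 percentage points higher from compound 3 to compound 4 (within the scatter), so this first reading of the position separates the 3-chloro-4-fluorophenyl and 3-chlorophenyl groups by no more than the usual scatter. The series also gains its first reading at the boron-bearing position: a group of 9 heavy atoms in place of a group of 3 heavy atoms on an aromatic carbon gives a number 5 percentage points higher from compound 2 to compound 4 (within the scatter), again with no order to be read in this assay. No independent measurement bears on either step.

The compounds shown leave open whether an amine or a longer chain in place of the hydrogen at this aromatic carbon would move the inhibition beyond the scatter, since fluoro and hydrogen are the only two groups compared there. They also leave open whether a carboxylic acid in place of the boron-bearing group would do so, and whether either position matters at concentrations other than the single one tested.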